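Moving the alkoxy group around the aryl ketone ring

The source may hold more compounds than are shown below. What is called first, only, known or untested is meant among the compounds shown, and "the series" means these compounds.

Of the compounds shown here, three that share one core have been tested in an assay on isolated protein for inhibition of annexin A2/S100-A10 (Homo sapiens), with a stated time of 5 min, tested at 50 uM; a lower number here means less inhibition, a higher number more inhibition at the concentration tested (going by the name of the read-out). Compound 1, `Cc1ccc(C(=O)C2=C(O)C(=O)N(CC(C)O)C2c2ccc(C(C)C)cc2)cc1`, gives 101% in this assay. Compound 2, `C=CCN1C(=O)C(O)=C(C(=O)c2ccc(C)cc2)C1c1ccc(C(C)C)cc1`, gives 105%; compound 3, `COc1cccc(C(=O)C2=C(O)C(=O)N(CC(C)O)C2c2ccc(C(C)C)cc2)c1`, gives 110%. All three numbers sit within the usual scatter of one another, so compound 3 is not set apart from the other two by the numbers on hand, and the three steps between them are all small: a number 4 percentage points higher from compound 1 to compound 2 (within the scatter), and a number 9 percentage points higher from compound 1 to compound 3 (within the scatter).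

Compound 4, `CCOc1ccccc1C(=O)C1=C(O)C(=O)N(CC(C)O)C1c1ccc(C(C)C)cc1`, has not yet been measured in this assay. It differs from compound 3 in one place: 2-ethoxyphenyl in place of 3-methoxyphenyl on a carbonyl carbon. Within the data shown here, the step that bears on it is the one from compound 1 to compound 3, where the aryl ring on the carbonyl carbon was also exchanged, and that step was a number 9 percentage points higher from compound 1 to compound 3 (within the scatter). Nothing in the numbers shown points to a change in the ring on the carbonyl carbon moving the read-out beyond the scatter, so the expected step for compound 4 is a number 6 percentage points lower from compound 3 to compound 4 (within the scatter). On that basis compound 4 is estimated to give 104% in this assay, with a likely range from 88% to 116%.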

Compound 4, a percentage reported as inhibition, at one concentration (the size of the read-out at that concentration, not a potency): 112%
The estimate for compound 4 lay 8 percentage points below the measured number, within the range that was stated.
By their numbers in this assay, from the lowest: compounds 1, 2, 3 and 4 (each within the scatter of the next, the first and the last beyond it).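

In this assay the exchange of 3-methoxyphenyl for 2-ethoxyphenyl on the carbonyl carbon comes out as a number 2 percentage points higher from compound 3 to compound 4 (within the scatter) and so cannot be told apart from repeat scatter, which means this position accepts the longer alkoxy chain on a different ring carbon without a measurable difference. Set against the 4-methylphenyl of compound 1, the same 2-ethoxyphenyl gives a number 11 percentage points higher from compound 1 to compound 4 (beyond the scatter) as the only step shown that passes the scatter, though it is modest and the 3-methoxyphenyl exchange stays inside it at a number 9 percentage points higher from compound 1 to compound 3 (within the scatter), so compounds 3 and 4 cannot be ranked against each other. No measurement is available that would explain these numbers.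

Both the length of the chain and its place on the ring differ between compound 3 and compound 4, so a 2-methoxyphenyl or a 3-ethoxyphenyl on the same carbonyl carbon would be needed to separate the two. Also open, as far as these compounds go, is how the read-out would respond to a ring carrying an amine or a carboxylic acid, or to a longer chain such as butoxy, at this position.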